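The source may hold more compounds than are shown below. What is called first, only, known or untested is meant among the compounds shown, and "the series" means these compounds.

Compound 1 `CCCCCCCOc1ccccc1C[C@H]1C(=O)OC[C@@H]1Cc1ccccc1` and compound 2 `Cc1ccccc1C[C@H]1C(=O)OC[C@@H]1Cc1ccccc1` share one core, and compound 3 `CCCCCCCOc1ccc(C[C@H]2C(=O)OC[C@@H]2Cc2ccccc2)cc1` carries the same atoms joined differently; the difference between the two cores is not broken down here. In a functional assay on HL-60 cells (Homo sapiens) for cytotoxicity, read by WST assay, with a stated time of 48 h (a higher number here means that more compound is needed for the effect, a lower number that less compound is needed), compound 1 gives 75000 nM. In this assay compound 2 gives 57000 nM. The change from compound 1 to compound 2 is methyl in place of heptyloxy on an aromatic carbon, and it made a step of a 1.3-fold lower number from compound 1 to compound 2 (0.12 log units; within the scatter). For compound 3 the reading in this assay is a limit of the assay and not a number, at > 100000 nM; this is the limit described as the limit of > 100000 nM in this assay, at which 1 of the 3 values shown sits.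

Compound 4 `Cc1ccc(C[C@H]2C(=O)OC[C@@H]2Cc2ccccc2)cc1` has not yet been measured in this assay. It differs from compound 3 by methyl in place of heptyloxy on an aromatic carbon. Among the compounds with values here, this is the same kind of change as the one from compound 1 to compound 2: in the pair compound 1 and compound 2 the place is ortho to a large group, whereas in the pair compound 3 and compound 4 it is para to a large group.

On the core of compound 3, the step from compound 3 to compound 4 in this assay is expected to be about a number no higher from compound 3 to compound 4 (the limit leaves the size open), resting on the step of a 1.3-fold lower number from compound 1 to compound 2 (0.12 log units; within the scatter) seen with the same change on the other core. Since compound 3 reached only a limit, compound 4 is estimated at 100000 nM, somewhere between 45000 nM and 250000 nM, with a fair chance that only a limit is reported again.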

Compound 4, half-maximal effective concentration: 44000 nM
The estimate for compound 4 lay 2.3-fold (0.36 log units) above the measured number; the whole stated range lies above it.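

In this assay, methyl in place of heptyloxy on an aromatic carbon, para to a large group, gave an at least 2.2-fold lower number from compound 3 to compound 4 (0.35 log units; beyond the scatter), so on the core of compound 3 this change goes with a lower number beyond the scatter, while on the core of compound 1 it stayed within the scatter. Set side by side, the two steps cannot be told apart: the same change on two cores in this assay, a 1.3-fold lower number (0.12 log units; within the scatter) from compound 1 to compound 2 and an at least 2.2-fold lower number (0.35 log units; beyond the scatter) from compound 3 to compound 4; the limit leaves it open whether they differ The series therefore shows neither that the step carries over from one core to the other with the same size nor that it depends on the core, since the reading for compound 3 is a limit and gives the step on that core only a lower bound.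

Among the methyl compounds, 4-methylphenyl in place of 2-methylphenyl gave a 1.3-fold lower number from compound 2 to compound 4 (0.11 log units; within the scatter), which leaves the two readings within the scatter of each other, whereas the heptyloxy pair has no such direct reading. The compounds shown leave open what a shorter chain such as ethoxy, a hydroxyl, an amine or a carboxylic acid would do in place of heptyloxy on either core, and whether any such step would match on both.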